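The source may hold more compounds than are shown below. What is called first, only, known or untested is meant among the compounds shown, and "the series" means these compounds.

Of the compounds shown here, three have been measured in a functional assay on the whole organism for inhibition, with Lemna aequinoctialis as the target, tested at 10 ug/mL; on this read-out higher numbers stand for more inhibition of growth at the one concentration tested and lower numbers for less inhibition of growth. Compound 1 `Cc1cccc(NC(=S)N/N=C2\C(=O)Nc3ccc([N+](=O)[O-])cc32)c1` gives 10%, compound 2 `Cc1ccc(NC(=S)N/N=C2\C(=O)Nc3ccc([N+](=O)[O-])cc32)cc1` gives 15% and compound 3 `O=C1Nc2ccc([N+](=O)[O-])cc2/C1=N/NC(=S)Nc1ccccc1C(F)(F)F` gives 10%. Compound 1 and compound 3 read the same, and together they stand lowest of the three numbers; compound 2 lies nearest above them, but the step of a number 5 percentage points higher from compound 1 to compound 2 (within the scatter) is within the scatter, so no ordering among the three can be claimed.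

Compound 4 `O=C1Nc2ccc([N+](=O)[O-])cc2/C1=N/NC(=S)Nc1ccc(F)cc1` has not been measured. It differs from compound 1 by 4-fluorophenyl in place of 3-methylphenyl on an amide-type nitrogen. Going by the values given here, the one measured step that bears on this change is the exchange of one aryl group for another on the same nitrogen, a number 5 percentage points higher from compound 1 to compound 2 (within the scatter), which stayed within the scatter. Among the compounds with values here, compound 3 carries a third aryl group at that position and shows no change against compound 1 at the digits given; no step is available for that pair beyond what the two values show.

Expected, therefore, is a step of a number 2 percentage points higher from compound 1 to compound 4 (within the scatter) that does not leave the scatter. Compound 4 is estimated at 12% in this assay, with a range from 0% to 25%.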

Compound 4, percent growth inhibition at one concentration: 5%
Compound 4: the middle estimate sits 7 percentage points above what was measured; the measured number falls inside the stated range.
By their numbers in this assay, from the lowest: compounds 4, 1, 3 and 2 (each within the scatter of the next).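

Compound 4 brings a fluorine-bearing aryl group to the amide-type nitrogen, and in this assay the exchange of 3-methylphenyl for 4-fluorophenyl is a number 5 percentage points lower from compound 1 to compound 4 (within the scatter) and stays within the scatter. Going by these compounds alone, the pair of compound 2 and compound 4 adds the first comparison of the two substituents alone, 4-methylphenyl against 4-fluorophenyl, and fluoro in place of methyl on an aromatic carbon is a number 10 percentage points lower from compound 2 to compound 4 (within the scatter) and also lies within the scatter, so methyl, trifluoromethyl and fluoro variants of the phenyl group at this position remain unseparated in this read-out. No independent measurement is at hand that would help interpret these small differences.

The compounds shown leave open whether any group on this nitrogen can move growth inhibition beyond the scatter, for example a carboxylic acid on the phenyl ring or a cyclohexyl group in place of that ring. The shared core is the same in all four compounds, and its part in the read-out remains an open question.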